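Swapping the Aryl Group on a Shared Core

The source may report more compounds than this note shows. Statements on the series, on what has been measured and on what is new or still open speak of the compounds shown alone.

Measured compounds:
compound 1, `C/C(=C\CC/C(C)=C/CC[C@@H]1[C@@]2(C)CCC(=O)C(C)(C)[C@H]2CC[C@@]1(C)O)CC/C=C(\C)C(=O)OCc1cn(-c2ccccc2Br)nn1`: > 150000 nM
compound 2, `C/C(=C\CC/C(C)=C/CC[C@@H]1[C@@]2(C)CCC(=O)C(C)(C)[C@H]2CC[C@@]1(C)O)CC/C=C(\C)C(=O)OCc1cn(-c2cccc(C)c2)nn1`: 137000 nM

In a functional assay on DU-145 cells (Homo sapiens) for antiproliferative activity, read by MTT assay, with a stated time of 48 h (on this read-out lower numbers stand for stronger inhibition and higher numbers for weaker inhibition), compound 1 gives > 150000 nM, which is a limit of the assay and not a number. Compound 2, whose value is a number, gives 137000 nM in this assay. For the measured compounds named here, the one measured step, an at least 1.0-fold lower number from compound 1 to compound 2 (0.03 log units; that floor lies within the scatter), changes only the aryl group on the aromatic nitrogen and stays within the scatter, with one value sitting at the limit of > 150000 nM in this assay, at which 1 of the 2 values shown sits.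

Compound 3, `COc1cccc(-n2cc(COC(=O)/C(C)=C/CC/C(C)=C/CC/C(C)=C/CC[C@@H]3[C@@]4(C)CCC(=O)C(C)(C)[C@H]4CC[C@@]3(C)O)nn2)c1`, differs from compound 1 in the same place: 3-methoxyphenyl in place of 2-bromophenyl on an aromatic nitrogen. Going by the values given here, the only step that bears on this change is an at least 1.0-fold lower number from compound 1 to compound 2 (0.03 log units; that floor lies within the scatter), an exchange of the same aryl group that produced no movement beyond the scatter. A similar exchange is therefore expected to leave the read-out where it stands, and the expected step is an at least 1.0-fold lower number from compound 1 to compound 3 (0.02 log units; that floor lies within the scatter). Compound 3 is accordingly estimated at 140000 nM in this assay, with a range from 60000 nM to 300000 nM, and a real chance that only a limit is reported again.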

Compound 3, half-maximal inhibitory concentration: > 150000 nM
Compound 3: no number, only a limit; the forecaster's own chance of this, stated with the estimate: 50%; at least 1.0-fold (0.02 log units) between middle value and limit.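

Compound 3 gives > 150000 nM in this assay, which is a limit of the assay and not a number. Methoxy in place of methyl on an aromatic carbon gives an at least 1.0-fold higher number from compound 2 to compound 3 (0.03 log units; that floor lies within the scatter), while the step between the two limits cannot be read. With a third aryl group now tried on the aromatic nitrogen, no exchange at this position has yet moved the read-out beyond the scatter, and most of the values rest at the edge of what the assay can report: the limit of > 150000 nM in this assay, at which 2 of the 3 values shown sit.

The compounds shown leave open whether any group at this position can bring the read-out down to a number clearly apart from the others, since a limit hides how far a compound lies past it. A phenyl ring carrying an amine or a carboxylic acid, or a benzyl group in place of the phenyl ring, would test whether this position can change the read-out at all.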